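Swapping an aryl amine substituent for an isopentyl chain

The compounds below may be only part of what the source reports. "The series", "measured", "known", "first", "only" and "open" are said of these compounds alone.

This account concerns two measured compounds and one that awaits measurement. Compound 1 `COc1ccc(NC[C@@H](O)COc2ccc(N3C[C@H](CNC(C)=O)OC3=O)cc2F)cc1` was tested in a physicochemical assay for lipophilicity, read by HPLC (a higher number here means a more lipophilic compound, a lower number a more polar compound), where compound 1 gives 1.15. Its companion, compound 2 `CC(=O)NC[C@H]1CN(c2ccc(OC[C@@H](O)CNc3ccccc3)c(F)c2)C(=O)O1`, gives 1.42 in this assay. The gap between these two numbers falls within the usual scatter of repeated measurements, so the data do not separate compound 1 from compound 2, and no order between them can be read from this pair.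

The unmeasured compound is compound 3 `CC(=O)NC[C@H]1CN(c2ccc(OC[C@H](O)CNCCC(C)C)c(F)c2)C(=O)O1`. It differs from compound 1 in a single place: isopentyl in place of 4-methoxyphenyl on an amine nitrogen. A 4-methoxyphenyl group leaves and an isopentyl group enters on the amine nitrogen whose other neighbour is a saturated chain carbon.

Among the compounds with values here, no measured pair in this set shows what such a change does in this assay, so the expectation rests on the structural change alone. The step expected from compound 1 to compound 3 is a number 0.65 log units lower from compound 1 to compound 3 (beyond the scatter), a fall in this assay that should exceed the scatter. Compound 3 is therefore estimated at 0.5, within a range from -0.3 to 1.3.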

Compound 3, partition coefficient: 1.19
The estimate for compound 3 lay 0.69 log units below the measured number, within the range that was stated.
By their numbers in this assay, from the lowest: compounds 1, 3 and 2 (each within the scatter of the next).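

In this assay, within the data shown here, the exchange of 4-methoxyphenyl for isopentyl on the amine nitrogen gives a number 0.04 log units higher from compound 1 to compound 3 (within the scatter), which is the first direct reading of this change at this position: a group with a six-membered aromatic ring and a group with no ring cannot be told apart here. The wider exchange of 2-anilino-1-hydroxyethyl for 1-hydroxy-2-(isopentylamino)ethyl gives a number 0.23 log units lower from compound 2 to compound 3 (within the scatter), so compound 1, compound 2 and compound 3 all stay unseparated in this assay, and no order among these amine substituents can be read. No supporting measurement is available that could account for this outcome.

From the compounds shown here alone, what remains open is whether another group on this amine nitrogen, such as a longer alkyl chain, a cyclohexyl ring or a chain ending in a carboxylic acid, would shift the number in this assay beyond the scatter. Among these compounds, it is also open whether isopentyl in place of 4-methoxyphenyl would read the same on a core other than the one shared by these compounds.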